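A few compounds are considered here, and "the series" means these few. Any claim that something is new, unique, unknown or untested is made for them only; others in the source may bear on it.

Measured so far:
- compound 1 `Cc1cc(C#N)cc(C)c1Oc1ccnc(SCC(=O)Nc2ccc(C#N)cc2)n1`: > 300000 nM
- compound 2 `Cc1cc(C#N)cc(C)c1Oc1ccnc(S(=O)(=O)CC(=O)Nc2cccc(F)c2)n1`: 25900 nM

The read-out is an ADME assay on MT4 cells (Homo sapiens) for cytotoxicity, read by MTT assay, with a stated time of 4 days; a lower number here means that less compound is tolerated, a higher number that more compound is tolerated. Compound 1 gives > 300000 nM, which is a limit of the assay and not a number. For the measured compounds named here, compound 2 gives 25900 nM, the only actual number so far.

Compound 3 `Cc1cc(C#N)cc(C)c1Oc1ccnc(S(=O)(=O)CC(=O)Nc2ccc(Cl)c(Cl)c2)n1` carries 3,4-dichlorophenyl in place of 3-fluorophenyl on an amide-type nitrogen, and otherwise matches compound 2 (3,4-dichlorophenyl in place of 3-fluorophenyl on an amide-type nitrogen). Going by the values given here, no measured step is available to size this change, so the expectation is anchored only on compound 2 at 25900 nM. A moderate downward move is expected in this assay, with less compound tolerated, and this expected step, a 2.2-fold lower number from compound 2 to compound 3 (0.33 log units; beyond the scatter), is a tentative one. For compound 3 the estimated value is 12000 nM, with an expected range of 4000 nM to 35000 nM.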

Compound 3, half-maximal cytotoxic concentration: 11700 nM
Compound 3: middle estimate off by 1.0-fold (0.01 log units), on the high side; the range from low to high includes it.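

For the compounds shown here, at this position, on the amide-type nitrogen, 3,4-dichlorophenyl in place of 3-fluorophenyl gives a 2.2-fold lower number from compound 2 to compound 3 (0.35 log units; beyond the scatter) in this assay, the only step that can be sized so far. The aryl group on this nitrogen therefore moves the read-out, in the direction of less compound tolerated, although the step is modest. Loss of the fluorine and gain of the two chlorine atoms come together in this one change, and their shares cannot be separated.

Still open, on these data alone, is how an amine or a carboxylic acid on this aryl ring, or a longer chain in its place, would read in this assay. Compound 1 differs from compound 2 in more than one place and offers no readable step, and its value is a limit of the assay and not a number: the limit of > 300000 nM in this assay, at which 1 of the 3 values shown sits.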